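Free acid at the ester oxygen: compound 1 to compound 4

A few compounds are considered here, and "the series" means these few. Any claim that something is new, unique, unknown or untested is made for them only; others in the source may bear on it.

Measured compounds:
compound 1 `C[C@H](NC(=O)CN(c1nc(Cl)nc2[nH]cnc12)C1CC1)C(=O)OCc1ccccc1` gives 36.1%
compound 2 `C[C@@H](O)[C@H](NC(=O)CN(c1nc(Cl)nc2[nH]cnc12)C1CC1)C(=O)OCc1ccccc1` gives 30.7%
compound 3 `CC(C)C[C@H](NC(=O)CN(c1nc(Cl)nc2[nH]cnc12)C1CC1)C(=O)OCc1ccccc1` gives 8.58%

All three were run in a functional assay on the whole organism (Tail, strain ICR) with Mus musculus as the target, in the tail flick test, with a stated time of 120 min, at a dose of 25 umol/kg by the oral route; on this read-out higher numbers stand for a stronger effect at the one dose given and lower numbers for a weaker effect. Compound 1 holds the highest of the three numbers; compound 2 sits nearest to it a number 5.4 percentage points lower from compound 1 to compound 2 (within the scatter), and compound 3 sits furthest a number 27.5 percentage points lower from compound 1 to compound 3 (beyond the scatter). Between compound 2 and compound 3 the step is a number 22.1 percentage points lower from compound 2 to compound 3 (beyond the scatter). Every measured step touches the saturated chain carbon that carries the side group, and none touches the ester.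

The step to compound 4 `C[C@H](NC(=O)CN(c1nc(Cl)nc2[nH]cnc12)C1CC1)C(=O)O` is of a different kind: hydrogen in place of benzyl on an oxygen next to a carbonyl group. For the measured compounds named here, no measured pair changes this oxygen, so none of the three steps bears on it, and the only anchor is the value of compound 1 in this assay. The expectation therefore rests on compound 1 alone, with a wide range and no direction claimed beyond the scatter.

For compound 4 the expected read-out in this assay is 28%, with a range from 6% to 50%. The step this estimate implies is a number 8.1 percentage points lower from compound 1 to compound 4 (within the scatter), expected rather than known.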

Compound 4, a percentage reported as activity, at one dose (the size of the read-out at that dose, not a potency): 28.4%
For compound 4 the middle estimate is 0.4 percentage points below the measured one; measured number inside the range.
By their numbers in this assay, from the lowest: compound 3; then compounds 4, 2 and 1 (each within the scatter of the next).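

In this assay, for the compounds shown here, the first measured change on an oxygen next to a carbonyl group, hydrogen in place of benzyl, gives a number 7.7 percentage points lower from compound 1 to compound 4 (within the scatter). Going by these compounds alone, at this single oral dose and time, the benzyloxycarbonyl group can therefore give way to carboxy with no step beyond the scatter, so the benzyl group and its six-membered aromatic ring of carbon only are not needed for a read-out of this size, something the earlier steps on the saturated chain carbon could not show. No measurement on hand explains this result.

From the compounds shown here alone, it remains open whether the same exchange would read alike with the other side groups, that is, whether carboxy in place of benzyloxycarbonyl would leave compound 2, with its 1-hydroxyethyl, and compound 3, with its isobutyl, within the scatter of their benzyl esters. Also open, going by these compounds, is how a methyl or ethyl group on this oxygen, or an amide with a nitrogen in place of the oxygen, would read, and whether any group here could move the read-out beyond the scatter.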